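Amine swap at the shared core: compound 3 to compound 4

The compounds below may be only part of what the source reports. "The series", "measured", "known", "first", "only" and "open" are said of these compounds alone.

Compound 1, `c1ccc(-c2ccc3oc(NC4CCCCC4)nc3c2)cc1`; in an assay on HEK293 cells for inhibition of Fatty-acid amide hydrolase 1 (Homo sapiens), read by fluorescence (a lower number here means a stronger inhibitor, a higher number a weaker inhibitor), compound 1 gives > 1000 nM, which is a limit of the assay.
Compound 2, `c1cnc2ccc(-c3ccc4oc(NC5CCCCC5)nc4c3)cc2c1`; in this assay compound 2 gives > 1000 nM, which is a limit of the assay.
Compound 3, `CN(c1ccccc1)c1nc2cc(-c3ccc4c(ccn4C)c3)ccc2o1`; in this assay compound 3 gives 68 nM.

Among the measured compounds shown here, compound 3 is the only compound of the three that returns a number in this assay. The other two values are limits. Compound 1 and compound 2 both sit at the limit of > 1000 nM in this assay, at which 2 of the 3 values shown sit. For the measured compounds named here, no pair of measured compounds differs in one place, so no measured step is available to calibrate the next change.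

Compound 4, `Cn1ccc2cc(-c3ccc4oc(N5CCNCC5)nc4c3)ccc21`, is the next compound and has not yet been measured in this assay. It differs from compound 3 as follows: piperazin-1-yl in place of methyl(phenyl)amino on an aromatic carbon. Going by the values given here, no step of this kind has been measured. The expectation therefore rests on the change itself. Compound 4 is expected to be a weaker inhibitor than compound 3, with the step of a 22-fold higher number from compound 3 to compound 4 (1.34 log units; beyond the scatter) expected to go beyond the scatter, and with a fair chance that only a limit is reported. Compound 4 is expected to give 1500 nM in this assay, within a range from 300 nM to 8000 nM.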

Compound 4, half-maximal inhibitory concentration: > 1000 nM
Compound 4: only a limit was reported; the forecaster's own chance of this, stated with the estimate: 55%; the middle value is on the limit's open side.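

Among the compounds shown here, the first measured step at this position, on the aromatic carbon next to the ring nitrogen and next to the ring oxygen, is large: piperazin-1-yl in place of methyl(phenyl)amino gives an at least 14-fold higher number from compound 3 to compound 4 (1.16 log units; beyond the scatter). As far as these compounds go, compound 4 gives > 1000 nM in this assay, which is a limit of the assay and not a number, so the full size of the step stays unknown. Compound 3 remains the only compound shown with a number, and the shared core with its indole-free neighbours aside, this swap moves it to the common limit: the limit of > 1000 nM in this assay, at which 3 of the 4 values shown sit.

This single pair does not separate the loss of the phenyl ring from the entry of the ring with its added hydrogen-bond donor. From the compounds shown here alone, how a morpholine ring or a benzyl(methyl)amino group would read at this position stays open.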